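Bromine in place of fluorine on the anilide of compound 1

A few compounds are considered here, and "the series" means these few. Any claim that something is new, unique, unknown or untested is made for them only; others in the source may bear on it.

Compound 1 `CN(C)C(=O)c1cc2cnc(Nc3ccc(NC(=O)C4(C(=O)Nc5ccc(F)cc5)CC4)cc3)nc2n1C1CCCC1` holds the higher of the two numbers measured: in a functional assay on SiHa cells (Homo sapiens) for inhibition, read by CCK-8 assay, with a stated time of 72 h, tested at 1 uM (on this read-out higher numbers stand for more inhibition of growth at the one concentration tested and lower numbers for less inhibition of growth), compound 1 gives 36.5%, and compound 2 `CN(C)C(=O)c1cc2cnc(Nc3ccc(NC(=O)C4(C(=O)Nc5ccc(Br)cc5)CC4)cc3)nc2n1C1CCCC1` gives 23.2%. The two differ only by bromo in place of fluoro on an aromatic carbon, and that step came out as a number 13.3 percentage points lower from compound 1 to compound 2 (beyond the scatter). Compound 3 `CN(C)C(=O)c1cc2cnc(Nc3ccc(NC(=O)C4(C(=O)Nc5cccc(Br)c5)CC4)cc3)nc2n1C1CCCC1` has not yet been measured; it differs from compound 1 as 3-bromophenyl in place of 4-fluorophenyl on an amide-type nitrogen. The step from compound 1 to compound 2 is the only measured one bearing on this change, since it also swaps fluorine for bromine on that ring. Going by the values given here, no measured pair shows the halogen moved to a different carbon of the same ring, so that part of the change is untested. Compound 3 is therefore expected to fall below compound 1 by a number 11.5 percentage points lower from compound 1 to compound 3 (beyond the scatter), an estimated 25% with a range from 10% to 40%.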

Compound 3, percent growth inhibition at one concentration: 13.9%
For compound 3 the middle estimate is 11.1 percentage points above the measured one; the measured number falls inside the stated range.
By their numbers in this assay, from the lowest: compounds 3 and 2 (each within the scatter of the next); then compound 1.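

In this assay, 3-bromophenyl in place of 4-bromophenyl on the amide-type nitrogen gives a number 9.3 percentage points lower from compound 2 to compound 3 (within the scatter), so moving the bromine on this ring produces no difference that can be separated from the usual scatter. The full change from 4-fluorophenyl to 3-bromophenyl gives a number 22.6 percentage points lower from compound 1 to compound 3 (beyond the scatter), which leaves both bromo compounds apart from compound 1, and compound 1 remains the highest of the three. Nothing shown here gives a reason for these numbers.

The compounds shown leave open how a 3-fluorophenyl, a 4-chlorophenyl, a 4-methoxyphenyl or an unsubstituted phenyl on this nitrogen would read against compound 1. Going by these compounds, every number also comes from a single concentration, so how these steps would look across a range of concentrations remains open.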